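Swapping the far aryl ether group of compound 1

This account rests on a few compounds, and the source may have more. Where it says the series, first, only, none or still open, it means among the compounds named here.

Measured in a functional assay on A549 cells (Homo sapiens) for cytotoxicity, read by MTT assay, with a stated time of 72 h; on this read-out lower numbers stand for stronger inhibition and higher numbers for weaker inhibition:
- Compound 1 `CNC(=O)c1cc(Oc2ccc(NC(=O)c3nn(-c4ccc(Br)cc4F)c(=O)cc3C)cc2F)ccn1`: 7930 nM
- Compound 2 `CNC(=O)c1cc(Oc2ccc(NC(=O)c3nn(-c4ccccc4OC(F)(F)F)c(=O)cc3C)cc2F)ccn1`: > 40000 nM (a limit of the assay, not a number)
- Compound 3 `CNC(=O)c1cc(Oc2ccc(NC(=O)c3nn(-c4cccc(F)c4)c(=O)cc3C)cc2F)ccn1`: 9540 nM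

Of the two true numbers, compound 1 gives 7930 nM and sits level with compound 3, with a 1.2-fold higher number from compound 1 to compound 3 (0.08 log units; within the scatter). Compound 4 `Cc1cc(=O)n(-c2ccc(Br)cc2F)nc1C(=O)Nc1ccc(Oc2ncnc3sccc23)c(F)c1` keeps the 4-bromo-2-fluorophenyl group of compound 1 and differs at one place: a group of 9 heavy atoms (6 carbon, 2 nitrogen, 1 sulfur; one five-membered aromatic ring with 1 hetero atom, one six-membered aromatic ring with 2 hetero atoms) in place of a group of 10 heavy atoms (7 carbon, 2 nitrogen, 1 oxygen; one six-membered aromatic ring with 1 hetero atom), on an oxygen on an aromatic ring. There, on an oxygen on an aromatic ring, the 2-(methylcarbamoyl)pyridin-4-yl group leaves.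

The measured steps bear on this only indirectly, since all of them change the group on an aromatic nitrogen. They show a 1.2-fold higher number from compound 1 to compound 3 (0.08 log units; within the scatter) for 3-fluorophenyl and an at least 5.0-fold higher number from compound 1 to compound 2 (0.70 log units; beyond the scatter) for 2-(trifluoromethoxy)phenyl. For the measured compounds named here, no measured step touches the place that changes in compound 4, so the size of the change is poorly constrained, and no step beyond the scatter is expected in this assay. The expected change is a 1.6-fold lower number from compound 1 to compound 4 (0.20 log units; within the scatter). For compound 4 the estimated value is 5000 nM, within an expected range of 1000 nM to 25000 nM.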

Compound 4, half-maximal inhibitory concentration: 11500 nM
Compound 4: middle estimate off by 2.3-fold (0.36 log units), on the low side; the measured number falls inside the stated range.
By their numbers in this assay, from the lowest: compounds 1, 3 and 4 (each within the scatter of the next). At a limit, above all of these: compound 2.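

In this assay, the exchange on the oxygen on an aromatic ring gives a 1.5-fold higher number from compound 1 to compound 4 (0.16 log units; within the scatter). For the compounds shown here, this is the first reading at this place, as the earlier compounds changed only the group on an aromatic nitrogen, and it shows that the 2-(methylcarbamoyl)pyridin-4-yl group, with its hydrogen-bond donor, can leave in favour of the two-ring group without a change beyond the scatter. Nothing given here explains this result.

The compounds shown leave open whether any group on this oxygen can move the number beyond the scatter, for example a pyridin-4-yl group carrying a carboxylic acid or an amine in place of the methylcarbamoyl group. They also leave open whether the exchange would give the same result with 3-fluorophenyl on the aromatic nitrogen.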